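A few compounds are considered here, and "the series" means these few. Any claim that something is new, unique, unknown or untested is made for them only; others in the source may bear on it.

Measured in a functional assay for inhibition, with Rattus norvegicus as the target; a lower number here means that less compound is needed, a higher number that more compound is needed for the effect:
- Compound 1 `CCCC[C@H](CC1CCCCC1)NCc1ccc(C(=O)N[C@@H](CCSC)C(=O)O)c(-c2ccccc2C)c1`: 4.3 nM
- Compound 2 `CSCC[C@H](NC(=O)c1ccc(CN(CCC2CCCCC2)C(=O)c2ccccc2)cc1-c1ccccc1C)C(=O)O`: > 1000 nM, a limit

Within the data shown here, compound 1 gives 4.3 nM, the only actual number in this assay so far, and so the only firm point of comparison. The entry for compound 2 is > 1000 nM, and this is a limit of the assay rather than a number. With a single numerical value, no ranking or trend can be drawn from these compounds.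

The next compound to be tested is compound 3 `CSCC[C@H](NC(=O)c1ccc(CN[C@H](CSc2ccccc2)CC2CCCCC2)cc1-c1ccccc1C)C(=O)O`. It keeps the core of compound 1 but has phenylsulfanyl in place of propyl on a saturated chain carbon, two bonds along the chain from an amine nitrogen. Among the measured compounds shown here, no measured step shows what this exchange does, so the expectation starts from compound 1 at 4.3 nM. No shift beyond the usual scatter is expected, although a larger move in either direction remains possible. The estimated change is a 1.4-fold higher number from compound 1 to compound 3 (0.14 log units; within the scatter). For compound 3 the expected value is 6 nM, within an estimated range of 1.5 nM to 30 nM.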

Compound 3, half-maximal effective concentration: 12 nM
For compound 3 the middle estimate is 2.0-fold (0.30 log units) below the measured one; the range from low to high includes it.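

In this assay, replacing propyl with phenylsulfanyl on a saturated chain carbon, two bonds along the chain from an amine nitrogen, gives a 2.8-fold higher number from compound 1 to compound 3 (0.45 log units; beyond the scatter), a modest step beyond the scatter. Among these compounds, this is the only measured step at this position, and it shows that a larger group carrying an aromatic ring and a sulfur atom can stand here with compound 3 still at 12 nM. Nothing measured in this set accounts for the size of the step.

The aromatic ring and the sulfur enter together, so the compounds shown do not tell which of them goes with the higher number, or whether the added size alone would give the same step. From the compounds shown here alone, it also remains open how a benzyl group, with carbon in place of the sulfur, a phenoxy group, with oxygen there, or a longer alkyl chain would read at this place in this assay.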